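Adding a Second Chlorine: From Compound 3 to Compound 4

The source may report more compounds than this note shows. Statements on the series, on what has been measured and on what is new or still open speak of the compounds shown alone.

Of the compounds shown here, three built on one shared core have been tested in a functional assay on HT-1080 cells (Homo sapiens) for cytotoxicity, read by MTT assay, with a stated time of 72 h; a lower number here means a stronger inhibitor, a higher number a weaker inhibitor. Compound 1 `COc1cccc(/C=C2\CCC/C(=C\c3ccccc3Br)C2=O)c1OC` gives 10800 nM. Among the measured compounds shown here, compound 2 `COc1cccc(/C=C2\CCC/C(=C\c3cc(Cl)cc(Cl)c3)C2=O)c1OC` gives 6100 nM, and the only single-change step among the measured compounds, a 1.8-fold lower number from compound 1 to compound 2 (0.25 log units; within the scatter), stays within the usual scatter. Compound 3 `COc1ccc(/C=C2\CCC/C(=C\c3ccccc3Cl)C2=O)cc1OC` gives 6800 nM in this assay; its number lies between those of compound 1 and compound 2, and each of those gaps is within the scatter, so the three compounds cannot be separated on these data.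

Compound 4 `COc1ccc(/C=C2\CCC/C(=C\c3ccc(Cl)c(Cl)c3)C2=O)cc1OC` awaits measurement in this assay. It differs from compound 3 in one place: 3,4-dichlorophenyl in place of 2-chlorophenyl on a double-bonded chain carbon bound to a double-bonded ring carbon. For the measured compounds named here, the one measured step that bears on a change of this kind, an exchange of one halogenated phenyl group for another at the same place, is a 1.8-fold lower number from compound 1 to compound 2 (0.25 log units; within the scatter), and it did not move the number beyond the scatter. Compound 2, which likewise carries two chlorines on the phenyl ring at this place, gives 6100 nM, close to the number of compound 3. The step of a 1.1-fold lower number from compound 3 to compound 4 (0.05 log units; within the scatter) is therefore expected to stay within the scatter. Compound 4 is estimated to give 6000 nM in this assay, with a range from 2500 nM to 14000 nM.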

Compound 4, half-maximal inhibitory concentration: 3100 nM
Estimate against measurement, compound 4: 1.9-fold (0.29 log units) above; measured number inside the range.
By their numbers in this assay, from the lowest: compounds 4, 2, 3 and 1 (each within the scatter of the next, the first and the last beyond it).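

In this assay the exchange at this place gives a 2.2-fold lower number from compound 3 to compound 4 (0.34 log units; beyond the scatter) and so passes beyond the scatter, though the step is modest. Among the compounds shown here, the only earlier step at this place, a 1.8-fold lower number from compound 1 to compound 2 (0.25 log units; within the scatter), stayed within the scatter, so compound 4 gives the first sign that exchanging one halogenated phenyl group for another on a double-bonded chain carbon bound to a double-bonded ring carbon can move the number. The step takes 2-chlorophenyl out and puts 3,4-dichlorophenyl in, which adds one chlorine and also changes the name of the substitution pattern, and nothing at hand accounts for the change in the number.

The compounds shown leave open whether the number follows the count of chlorines or the way they are arranged on the phenyl ring, and whether the same exchange would give a step of like size on the core of compound 1. They also leave open how a phenyl group carrying an amine, a carboxylic acid or a nitrile would read at this place, where every group shown is a halogenated phenyl.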